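Working notes on compounds 1 to 3

The source may report more compounds than this note shows. Statements on the series, on what has been measured and on what is new or still open speak of the compounds shown alone.

Of the compounds shown here, two carry numbers so far. Compound 1, `COc1cc(/C=C/C(=O)/C=C(/C=C/c2ccc(O)c(OC)c2)NCCO)ccc1O`, gives in an ADME assay on CHO-K1 cells (Cricetulus griseus) for activation, read by fluorescence, tested at 1 uM (on this read-out higher numbers stand for a weaker effect at the one concentration tested and lower numbers for a stronger effect), a value of 93.5%. Compound 2, `O=C(/C=C(/C=C/c1ccc(O)cc1)NCCCO)/C=C/c1ccc(O)cc1`, gives in this assay a value of 86.4%. On the numbers shown compound 2 holds the smaller of the two figures, but the gap to compound 1 lies within the scatter, so no ordering of the two follows from it, and no step between measured compounds is recorded for this series.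

Compound 3, `COCCNC(=C\C(=O)/C=C/c1ccc(O)cc1)/C=C/c1ccc(O)cc1`, is still to be measured in this assay. It has the same atoms as compound 2, joined differently: methoxy in place of hydroxymethyl on a saturated chain carbon, two bonds along the chain from an amine nitrogen. Going by the values given here, the measured pair contains no change of this kind, and the one comparison available, compound 1 against compound 2, shows nothing beyond the scatter. The step of a number 1.6 percentage points higher from compound 2 to compound 3 (within the scatter) is therefore expected to be none beyond the scatter, in either direction. Compound 3 is expected to give 88% in this assay, with a range from 72% to 100%.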

Compound 3, a percentage reported as activity, at one concentration (the size of the read-out at that concentration, not a potency): 82.5%
Estimate against measurement, compound 3: 5.5 percentage points above; low and high end bracket the measured number.
By their numbers in this assay, from the lowest: compounds 3, 2 and 1 (each within the scatter of the next, the first and the last beyond it).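

Going by these compounds alone, this is the first step recorded, and it concerns a single place: on a saturated chain carbon, two bonds along the chain from an amine nitrogen, methoxy in place of hydroxymethyl gives in this assay a number 3.9 percentage points lower from compound 2 to compound 3 (within the scatter). The two groups have the same heavy-atom count and the same hydrogen-bond acceptor count, and they differ by the one hydrogen-bond donor of hydroxymethyl, so in this single pair the read-out shows no dependence on that donor beyond the scatter. Within the data shown here, nothing measured so far offers a reason for this outcome.

Among these compounds, the pair tests only one exchange of two closely matched neutral groups, so it leaves open whether a carboxylic acid, an amine or a longer chain at the end of the same chain would move the read-out in this assay beyond the scatter. It also leaves open whether methoxy in place of hydroxymethyl would behave the same way on the 2-hydroxyethyl chain of compound 1, whose core carries further groups, since one pair cannot show that the result carries over to another setting.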